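Restoring a Longer Chain After Trimming Helped

This account rests on a few compounds, and the source may have more. Where it says the series, first, only, none or still open, it means among the compounds named here.

Among the compounds with values here, compound 2 `COc1ccc(N(C)c2nc(C)nc3ccccc23)cc1[Se]C#N` gives 49 nM in a functional assay on A549 cells (Homo sapiens) for inhibition, read by MTT assay, with a stated time of 48 h (on this read-out higher numbers stand for weaker inhibition and lower numbers for stronger inhibition), the lowest of the two numbers measured so far. Compound 1 `COc1ccc(N(C)c2nc(C)nc3ccccc23)cc1C(=O)OCCC[Se]C#N` gives 250 nM in this assay; the step of a 5.1-fold lower number from compound 1 to compound 2 (0.71 log units; beyond the scatter) accompanied a shrinking of the group on the aromatic carbon. Compound 3 `COc1ccc(N(C)c2nc(C)nc3ccccc23)cc1OCCCCC[Se]C#N` moves back toward a larger group: a group of 9 heavy atoms (6 carbon, 1 nitrogen, 1 oxygen, 1 selenium; no ring) in place of a group of 3 heavy atoms (1 carbon, 1 nitrogen, 1 selenium; no ring), on an aromatic carbon. Because a 5.1-fold lower number from compound 1 to compound 2 (0.71 log units; beyond the scatter) favored the smaller group, a higher number of comparable size is expected for compound 3, namely a 4.1-fold higher number from compound 2 to compound 3 (0.61 log units; beyond the scatter). Compound 3 is therefore estimated at 200 nM, with a range from 70 nM to 600 nM.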

Compound 3, half-maximal inhibitory concentration: 2440 nM
Beside the measured number, compound 3's estimate is 12-fold (1.09 log units) below it; measured number above the stated range.
By their numbers in this assay, from the lowest: compound 2; then compound 1; then compound 3.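

On this aromatic carbon, in this assay, the larger group comes at a heavy cost, with a 50-fold higher number from compound 2 to compound 3 (1.70 log units; beyond the scatter). Size alone does not set the number here: two groups of 9 heavy atoms, one holding a carbonyl and the other a plain chain joined through oxygen, are separated by a 9.8-fold higher number from compound 1 to compound 3 (0.99 log units; beyond the scatter). No measurement at hand explains either step.

It remains open how the number changes with chain length between these groups, since only these three compounds are shown. A shorter chain, or one ending in an amine, could show whether the number rises gradually or abruptly.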